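A few compounds are considered here, and "the series" means these few. Any claim that something is new, unique, unknown or untested is made for them only; others in the source may bear on it.

Measured so far in a functional assay on HT-29 cells (Homo sapiens) for antiproliferative activity; on this read-out higher numbers stand for weaker inhibition and lower numbers for stronger inhibition:

compound 1 `CC(C)CC(=O)Nc1cccc(-c2ccnc3c(C(=O)c4cccs4)cnn23)c1` — 36 nM
compound 2 `CC(C)CNC(=O)c1cccc(-c2ccnc3c(C(=O)c4cccs4)cnn23)c1` — 150 nM

Compound 1 gives the lowest of the two numbers in this assay. Its nearest neighbour is compound 2, which turns the (isobutylcarbonyl)amino linker round into isobutylcarbamoyl; that step is a 4.2-fold higher number from compound 1 to compound 2 (0.62 log units; beyond the scatter), a modest loss beyond the scatter.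

Compound 3 `CC(C)CCNc1cccc(-c2ccnc3c(C(=O)c4cccs4)cnn23)c1` is the next to be measured. It differs from compound 1 in one place: isopentyl in place of isobutylcarbonyl on a nitrogen on an aromatic ring. The amide of compound 1 is thus cut back to a plain isopentylamino chain of the same length on the same aromatic nitrogen.

For the measured compounds named here, only the step from compound 1 to compound 2 bears on this change, and only loosely: it kept an amide and moved it, whereas compound 3 removes the carbonyl altogether. That one reading suggests the linker of compound 1 is not freely interchangeable, so a loss of potency in this assay is expected for compound 3, probably of modest size, a 3.1-fold higher number from compound 1 to compound 3 (0.49 log units; beyond the scatter), though the direction is not secured by any measured pair. The estimate for compound 3 in this assay is 110 nM, within 30 nM to 450 nM.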

Compound 3, half-maximal inhibitory concentration: 450 nM
Estimate against measurement, compound 3: 4.1-fold (0.61 log units) below; the range from low to high includes it.
By their numbers in this assay, from the lowest: compound 1; then compound 2; then compound 3.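

In this assay, for the compounds shown here, isopentyl in place of isobutylcarbonyl on the nitrogen gives the largest step so far, a 13-fold higher number from compound 1 to compound 3 (1.10 log units; beyond the scatter), which exceeds the cost of turning the linker round, a 4.2-fold higher number from compound 1 to compound 2 (0.62 log units; beyond the scatter). The plain isopentylamino chain also trails the reversed amide, with a 3.0-fold higher number from compound 2 to compound 3 (0.48 log units; beyond the scatter), so among these three compounds both linkers that keep a carbonyl give lower numbers than the linker without one, and no compound shown goes against this. No measurement here gives a reason for the size of this loss.

With a single amine compound, the result does not separate the loss of the carbonyl from any other difference between the isobutylcarbonyl and isopentyl chains. A urea or sulfonamide linker on the same aromatic carbon would show how far other linkers can stand in for the amide of compound 1, while a shorter acyl chain such as acetyl or a longer one such as hexanoyl would show how much the chain itself contributes.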